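This account rests on a few compounds, and the source may have more. Where it says the series, first, only, none or still open, it means among the compounds named here.

Measured so far in a functional assay on PC-3 cells (Homo sapiens) for antiproliferative activity, read by MTT assay, tested at 1 uM; a higher number here means a stronger effect of the compound at the concentration tested, a lower number a weaker effect:
compound 1, `COc1cc(C2=NN(C(C)=O)C(c3cccc(OC)c3OC)O2)cc(OC)c1OC`, 35%
compound 2, `COc1ccc(OC)c(/C=N/NC(=O)c2cc(OC)c(OC)c(OC)c2)c1`, 30.9%
compound 3, `COc1cc(C(=O)N/N=C/c2ccc(F)cc2)cc(OC)c1OC`, 76%

Compound 1 is second highest of the three numbers in this assay. Compound 2 lies within the scatter of it, while compound 3 stands well beyond the scatter above both.

Compound 4, `COc1cc(C2=NN(C(C)=O)C(c3cccc(F)c3)O2)cc(OC)c1OC`, is not yet measured. It differs from compound 1 by 3-fluorophenyl in place of 2,3-dimethoxyphenyl on a saturated ring carbon.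

Within the data shown here, no step between measured compounds is known for this change. In this assay compound 3 and compound 2 show a fluorophenyl-bearing compound with the higher value and a dimethoxyphenyl-bearing one with the lower, on a different core. For compound 4 an upward step of moderate size, beyond the scatter, is expected: a number 15 percentage points higher from compound 1 to compound 4 (beyond the scatter). Compound 4 is estimated at 50%, range 30% to 72%.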

Compound 4, a percentage reported as inhibition, at one concentration (the size of the read-out at that concentration, not a potency): 16.5%
Compound 4: the middle estimate sits 33.5 percentage points above what was measured; the whole stated range lies above it.
By their numbers in this assay, from the lowest: compound 4; then compounds 2 and 1 (each within the scatter of the next); then compound 3.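

In this assay, among these compounds, the only step read so far at the saturated ring carbon of the shared core is downward: 3-fluorophenyl in place of 2,3-dimethoxyphenyl gives a number 18.5 percentage points lower from compound 1 to compound 4 (beyond the scatter). On this core, 2,3-dimethoxyphenyl therefore holds the higher number of the pair, and a fluorinated aryl group brings no gain here. No measured evidence bears on the reason for this step. Still open, on these data alone, is whether the step follows the loss of the methoxy groups or the arrival of fluorine, and how an unsubstituted phenyl or a pyridine ring would read on the same carbon.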